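The source may hold more compounds than are shown below. What is called first, only, known or untested is meant among the compounds shown, and "the series" means these compounds.

Of the compounds shown here, two have been measured here. Compound 1, `c1ccc(CCc2ccccc2CSc2nccs2)cc1`, was tested in an assay on isolated protein for inhibition of Indoleamine 2,3-dioxygenase 1 (Homo sapiens), with a stated time of 60 min, tested at 10 uM (a lower number here means less inhibition, a higher number more inhibition at the concentration tested (going by the name of the read-out)), and compound 1 gives 31% in that assay. Compound 2, `Clc1ccc2[nH]c(SCc3ccccc3Oc3ccccc3)nc2c1`, shares the thioether-linked benzyl motif but carries a different core; in this assay compound 2 gives 30%. For the measured compounds named here, the two numbers lie within the usual scatter of each other, so compound 2 and compound 1 cannot be told apart on this evidence, and no step between measured compounds is available.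

Compound 3, `Clc1ccc2[nH]c(SCc3ccccc3/C=C\c3ccccc3)nc2c1`, is the next compound to be examined. It keeps the core of compound 2 and differs in a single place: 2-phenylethenyl in place of phenoxy on an aromatic carbon. Going by the values given here, because the only measured pair, compound 2 at 30% and compound 1 at 31%, gives no guidance on this kind of exchange, the size and direction of the change in this assay are uncertain, and a step no larger than the scatter is the most reasonable expectation.

On that basis compound 3 is estimated to give 35% in this assay, with a likely range from 10% to 60%. The expected step of a number 5 percentage points higher from compound 2 to compound 3 (within the scatter) is therefore small.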

Compound 3, a percentage reported as inhibition, at one concentration (the size of the read-out at that concentration, not a potency): 49%
For compound 3 the middle estimate is 14 percentage points below the measured one; the measured number falls inside the stated range.
By their numbers in this assay, from the lowest: compounds 2 and 1 (each within the scatter of the next); then compound 3.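

In this assay, for the compounds shown here, putting 2-phenylethenyl in place of phenoxy on this aromatic carbon gives a number 19 percentage points higher from compound 2 to compound 3 (beyond the scatter), the first step in this set that stands clear of the usual scatter, so the group held here does affect the read-out. Both groups carry a six-membered aromatic ring of carbon only, and the exchange removes the oxygen and its hydrogen-bond acceptor while bringing in a double bond outside aromatic rings, so in this pair the number rises without that oxygen. Nothing measured here says which of these differences accounts for the step.

The compounds shown leave open whether a different group in this same place, such as an amine, a carboxylic acid or a longer chain ending in the aromatic ring, would raise the number further or lower it. As far as these compounds go, they also leave open whether the step would hold on another core, and since each number is a read-out at a single concentration, how the potency of compound 3 compares with that of compound 2 remains unknown.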